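This account rests on a few compounds, and the source may have more. Where it says the series, first, only, none or still open, it means among the compounds named here.

Measured so far in a functional assay on HCC 2998 cells (Homo sapiens) for antiproliferative activity; a higher number here means a weaker inhibitor of growth, a lower number a stronger inhibitor of growth:
- compound 1 `Oc1ccc(-c2nc3ccccc3s2)cc1O`: 6990 nM
- compound 2 `COc1ccc(-c2nc3cc(F)ccc3s2)cc1F`: 13700 nM

Compound 2, at 13700 nM, lies within the usual scatter of compound 1, at 6990 nM, so these two values set no order. The next compound to be read in this assay is compound 3 `COc1ccc(-c2nc3cc(F)ccc3s2)cc1OC`. Relative to compound 2, it carries methoxy in place of fluoro on an aromatic carbon, ortho to a methoxy group and meta to a large group: methoxy in place of fluoro on an aromatic carbon.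

For the measured compounds named here, no measured pair differs in one place only, so there is no direct guide to the size of this step. The two available values do not separate beyond the scatter, which gives no reason to expect a large move. A small shift towards a lower number is the working expectation, with no step beyond the scatter. The expected step is a 1.4-fold lower number from compound 2 to compound 3 (0.14 log units; within the scatter). For compound 3 the estimated value is 10000 nM, with an expected range of 3000 nM to 35000 nM.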

Compound 3, concentration for 50% growth inhibition: 0.25 nM
Estimate against measurement, compound 3: 40000-fold (4.60 log units) above, and the stated range ends above it.
By their numbers in this assay, from the lowest: compound 3; then compounds 1 and 2 (each within the scatter of the next).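

At this position, on an aromatic carbon ortho to a methoxy group and meta to a large group, this assay shows an extreme sensitivity to a single exchange: methoxy in place of fluoro gives a 55000-fold lower number from compound 2 to compound 3 (4.74 log units; beyond the scatter), a large step. This places compound 3 at 0.25 nM. For the compounds shown here, compound 1 and compound 2 differ in more than one place and could not reveal this, so this pair is the first direct reading of any single change. Methoxy enters with 2 heavy atoms and 1 hydrogen-bond acceptor where fluoro leaves with 1 heavy atom and 0 hydrogen-bond acceptors, but no measurement at hand bears on what lies behind a step of this size.

Going by these compounds, whether a hydroxy group, an ethoxy group or an amine on this same carbon would hold the low number remains open, so it cannot yet be said how specific the requirement for methoxy is. Going by these compounds alone, also open is whether the step carries over to other substitution on the shared core, since this single pair is the only reading of the change.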